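Carbamoyl to nitro on the shared core

This account rests on a few compounds, and the source may have more. Where it says the series, first, only, none or still open, it means among the compounds named here.

compound 1 `Cc1cc(/C=C/C#N)cc(C)c1Oc1cc(Nc2ccc(C#N)cc2)c(N)cc1C(N)=O` gives 0.583 h
compound 2 `CNC(=O)c1cc(N)c(Nc2ccc(C#N)cc2)cc1Oc1c(C)cc(CCC#N)cc1C` gives 0.928 h

Among the compounds with values here, in an in vitro ADME assay on microsomes from liver (Homo sapiens) for metabolic stability, tested at 1 uM (a lower number here means that the compound disappears faster, a higher number that the compound lasts longer), the values of compound 1 and compound 2 lie within the usual scatter of each other, so compound 1 does not stand apart from the only other number. Compound 3 `Cc1cc(/C=C/C#N)cc(C)c1Oc1cc(Nc2ccc(C#N)cc2)c(N)cc1[N+](=O)[O-]` has not yet been measured. Its difference from compound 1 nitro in place of carbamoyl on an aromatic carbon is nitro in place of carbamoyl on an aromatic carbon, with the rest of the structure unchanged. Within the data shown here, no measured pair shows this change on its own, so the data give neither its size nor its direction. The working expectation is therefore no step beyond the scatter, with a range left wide on both sides. The expectation starts from compound 1 at 0.583 h as the closest structure with a number. The expected step of a 1.0-fold higher number from compound 1 to compound 3 (0.01 log units; within the scatter) is small on this basis. Compound 3 is estimated at 0.6 h with an expected range from 0.25 h to 1.4 h in this measurement.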

Compound 3, half-life: 0.797 h
Beside the measured number, compound 3's estimate is 1.3-fold (0.12 log units) below it; the range from low to high includes it.
By their numbers in this assay, from the lowest: compounds 1, 3 and 2 (each within the scatter of the next).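

In this assay, this position now has its first pair that differs in one place, and nitro in place of carbamoyl on the aromatic carbon gives a 1.4-fold higher number from compound 1 to compound 3 (0.14 log units; within the scatter) on the core of compound 1. Within the data shown here, the change therefore has a measured size for the first time, and on this core that size does not separate nitro from carbamoyl in half-life, even though the two groups differ in hydrogen-bond donors, with 1 on carbamoyl and 0 on nitro. Nothing at hand bears on the cause of this result.

From the compounds shown here alone, the reading rests on a single pair, so it remains open whether nitro and carbamoyl would also stay within the scatter of each other on a core carrying a different side chain, such as the saturated cyanoethyl chain of compound 2. Also open, going by these compounds, is whether a carboxylic acid, a methyl ester or an aminomethyl group on this aromatic carbon, ortho to a large group and para to the (4-cyanophenyl)amino group, would move the half-life beyond the scatter in either direction.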